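The compounds below may be only part of what the source reports. "The series", "measured", "known", "first", "only" and "open" are said of these compounds alone.

Compound 2 `Clc1ccccc1CSc1nnc(-c2ccncc2)n1-c1ccccc1` and compound 3 `O=C(CSc1nnc(-c2ccncc2)n1-c1ccccc1)N/N=C/c1ccc(Cl)cc1` carry the same core, but the difference between the two cores is not broken down here. In a functional assay on HepG2 cells (Homo sapiens) for inhibition, read by MTT assay, with a stated time of 48 h (on this read-out higher numbers stand for weaker inhibition and lower numbers for stronger inhibition), compound 2 gives 15700 nM. In this assay compound 3 gives 11000 nM, which sits within the scatter of compound 2. Compound 1 `Fc1ccccc1CSc1nnc(-c2ccncc2)n1-c1ccccc1` differs from compound 2 by fluoro in place of chloro on an aromatic carbon. Compound 1 reaches only a limit of this assay, > 50000 nM. The step of an at least 3.1-fold higher number from compound 2 to compound 1 (0.50 log units; beyond the scatter) accordingly rests on the limit of > 50000 nM in this assay, at which 1 of the 3 values shown sits, and its size is known only as a lower bound. Compound 4 `O=C(CSc1nnc(-c2ccncc2)n1-c1ccccc1)N/N=C/c1ccc(F)cc1` differs from compound 3 by fluoro in place of chloro on an aromatic carbon, the same kind of change, though here the fluoro sits para to a large group rather than ortho to a large group. From this change the step of a 2.9-fold higher number from compound 3 to compound 4 (0.46 log units; beyond the scatter) is expected, resting on an at least 3.1-fold higher number from compound 2 to compound 1 (0.50 log units; beyond the scatter). Compound 4 is therefore estimated at 32000 nM in this assay, between 12000 nM and 90000 nM, with a real chance that only a limit is reported.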

Compound 4, half-maximal inhibitory concentration: 9330 nM
Estimate against measurement, compound 4: 3.4-fold (0.54 log units) above, outside the stated range (below it).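

In this assay the new step is a 1.2-fold lower number from compound 3 to compound 4 (0.07 log units; within the scatter), so fluoro in place of chloro does not repeat on this core what it did on the core of compound 1: the same change on two cores in this assay, an at least 3.1-fold higher number (0.50 log units; beyond the scatter) from compound 2 to compound 1 and a 1.2-fold lower number (0.07 log units; within the scatter) from compound 3 to compound 4, at least 3.7-fold (0.57 log units) apart, beyond the scatter of two such steps. The value of compound 1 is a limit and not a number, so the gap between the two steps is known only as a lower bound: the limit of > 50000 nM in this assay, at which 1 of the 4 values shown sits. The result shows that the step on one core gave no guide to the step on the other in these two pairs; it does not show why they part, and two pairs set no rule for the series.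

Still open, going by these compounds, is whether a methoxy group, an amine or a carboxylic acid in place of the fluoro of the 4-fluorophenyl group would shift the number in this assay. Also open, on these data alone, is how the same change behaves on further cores.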